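Swapping chloro for methoxy on compound 3

This account rests on a few compounds, and the source may have more. Where it says the series, first, only, none or still open, it means among the compounds named here.

Compound 1 `FC(F)(F)c1ccc(C2CC(c3ccc(Cl)cc3)=NN2c2ccc(-c3ccccc3)nn2)cc1` is the only one of the three measured compounds with a readable number: in a functional assay on HepG2 cells (Homo sapiens) for antiproliferative activity, read by MTT assay, with a stated time of 24 h (a higher number here means a weaker inhibitor, a lower number a stronger inhibitor), compound 1 gives 8330 nM. Compound 2 `COc1ccc(C2CC(c3ccc(Cl)cc3)=NN2c2ccc(-c3ccccc3)nn2)c(OC)c1` reaches only a limit of the assay, and in this assay compound 2 gives > 100000 nM. Compound 3 `COc1cc(C2CC(c3ccc(Cl)cc3)=NN2c2ccc(-c3ccccc3)nn2)cc(OC)c1OC` stands at the same place, since in this assay compound 3 gives > 100000 nM, again a limit and not a number. Both sit at the limit of > 100000 nM in this assay, at which 2 of the 3 values shown sit.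

The two readable steps, an at least 12-fold higher number from compound 1 to compound 2 (1.07 log units; beyond the scatter) and an at least 12-fold higher number from compound 1 to compound 3 (1.07 log units; beyond the scatter), each swap the 4-(trifluoromethyl)phenyl on the saturated ring carbon for a methoxy-bearing phenyl, and both are large. The step that the two limits leave unreadable from compound 2 to compound 3 cannot be read.

Compound 4 `COc1ccc(C2=NN(c3ccc(-c4ccccc4)nn3)C(c3cc(OC)c(OC)c(OC)c3)C2)cc1` differs from compound 3 by methoxy in place of chloro on an aromatic carbon. For the measured compounds named here, none of the measured steps touches this aryl group, so no direction can be drawn from them; what is known is only that compound 3 already sits at the limit. The step from compound 3 to compound 4 is therefore expected to be a number no higher from compound 3 to compound 4 (the limit leaves the size open), that is, nothing clearly beyond the scatter. In this assay compound 4 is accordingly expected to give about 100000 nM, with a range from 30000 nM to 300000 nM, most likely again reported only as a limit.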

Compound 4, half-maximal inhibitory concentration: > 100000 nM
Compound 4: a limit, no number; the forecaster's own chance of this, stated with the estimate: 70%; the middle value sits exactly at the limit.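

Compound 3 and compound 4 both stand only at a limit and not at a number, so no new step can be read between them in this assay: the limit of > 100000 nM in this assay, at which 3 of the 4 values shown sit.

The compounds shown leave open what 4-methoxyphenyl in place of 4-chlorophenyl does to the activity, as neither compound of this pair has a readable number.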